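A Chlorine Added to a Weak Adenosine Ligand

The source may hold more compounds than are shown below. What is called first, only, known or untested is meant among the compounds shown, and "the series" means these compounds.

Compound 1 `CCCn1c(=O)c2nc(-c3cnn(-c4ccccc4)c3C(F)(F)F)[nH]c2n(CCC)c1=O` was tested in an in vitro assay on HEK293 cells for displacement of a labelled ligand from adenosine receptor A2b (Homo sapiens); on this read-out lower numbers stand for stronger inhibition and higher numbers for weaker inhibition. In this assay compound 1 gives only a limit, > 6600 nM, not a number. The companion compound 2 `CCCn1c(=O)c2nc(-c3cnn(Cc4cc(F)ccc4Cl)c3)[nH]c2n(CCC)c1=O` gives 4800 nM in this assay. Compound 3 `CCCn1c(=O)c2nc(-c3cnn(-c4ccc(Cl)cc4)c3C(F)(F)F)[nH]c2n(CCC)c1=O` differs from compound 1 by a single change: chloro in place of hydrogen on an aromatic carbon. With compound 1 sitting at the limit of > 6600 nM in this assay, at which 1 of the 2 values shown sits, no measured pair sizes this step, so the expectation is a step of no more than the scatter, written as an at least 1.3-fold lower number from compound 1 to compound 3 (0.12 log units; that floor lies within the scatter). Compound 3 is therefore expected to give about 5000 nM, most likely between 1500 nM and 20000 nM.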

Compound 3, inhibition constant: > 6600 nM
Compound 3 ended at the assay's limit; the forecaster's own chance of this, stated with the estimate: 50%; at least 1.3-fold (0.12 log units) between middle value and limit.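

No step from compound 1 to compound 3 can be read, because both compounds give a limit rather than a number: the limit of > 6600 nM in this assay, at which 2 of the 3 values shown sit.

From the compounds shown here alone, whether phenyl to 4-chlorophenyl changes inhibition in this assay at all stays open.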